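The compounds below may be only part of what the source reports. "The series", "measured", "known", "first", "only" and "open" are said of these compounds alone.

Measured so far:
Compound 1: `COc1ccccc1-n1cc(COc2c(/C=C\C(=O)O)ccc(OC)c2CC=C(C)C)nn1` gives 32200 nM
Compound 2: `COc1ccc(/C=C\C(=O)O)c(OCc2cn(-c3ccccc3)nn2)c1CC=C(C)C` gives 26000 nM

For the measured compounds named here, in a functional assay on HCT-116 cells (Homo sapiens) for cytotoxicity, read by MTT assay, with a stated time of 24 h (a lower number here means a stronger inhibitor, a higher number a weaker inhibitor), compound 2 gives 26000 nM, the lowest of the two numbers available, but its only neighbour, compound 1 at 32200 nM, lies within the scatter of it, so neither compound can be called the stronger. Going by the values given here, the single step known is a 1.2-fold lower number from compound 1 to compound 2 (0.09 log units; within the scatter), brought about by hydrogen in place of methoxy on an aromatic carbon.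

Compound 3, `COc1ccc(/C=C\C(=O)O)c(OCc2cn(-c3ccccc3C(=O)N3CCC(O)C3)nn2)c1CC=C(C)C`, carries (3-hydroxypyrrolidin-1-yl)carbonyl in place of hydrogen on an aromatic carbon. Among the compounds with values here, the one step recorded also altered a substituent on an aromatic carbon and stayed within the scatter, yet the group entering here is far larger than a methoxy, so the precedent is thin. No step beyond the scatter is expected in this assay. Compound 3 is therefore estimated at 22000 nM, with a range from 7000 nM to 70000 nM. That estimate implies an expected step of a 1.2-fold lower number from compound 2 to compound 3 (0.07 log units; within the scatter).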

Compound 3, half-maximal inhibitory concentration: 32000 nM
The estimate for compound 3 lay 1.5-fold (0.16 log units) below the measured number; measured number inside the range.
By their numbers in this assay, from the lowest: compounds 2, 3 and 1 (each within the scatter of the next).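

On the six-membered aromatic ring of carbon only, the position ortho to a large group has now carried (3-hydroxypyrrolidin-1-yl)carbonyl, with its 8 heavy atoms, as well as hydrogen and methoxy, and this assay does not tell the three apart (a 1.2-fold higher number from compound 2 to compound 3 (0.09 log units; within the scatter); a 1.0-fold lower number from compound 1 to compound 3 (0.00 log units; within the scatter)). For the compounds shown here, the earlier compounds compared only hydrogen with methoxy, so this is the first sign that a much larger group with a non-aromatic ring can sit here without a step beyond the scatter. Nothing measured here explains this lack of separation.

The compounds shown leave open whether an amine, a carboxylic acid or a longer chain at this position would move the number beyond the scatter. They also leave open whether any change here can give a clearly stronger inhibitor in this assay.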